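Mirror image of compound 1 in the receptor assay

The compounds below may be only part of what the source reports. "The series", "measured", "known", "first", "only" and "open" are said of these compounds alone.

compound 1 `Cc1csc2c(-n3nc(Nc4ccc(N5CCN([C@@H]6C[C@H]7CC[C@@H]6C7)CC5)c(Cl)c4)nc3N)nc(Cl)nc12`: 216 nM
compound 2 `COc1cc2ncnc(-n3nc(Nc4ccc(N5CCN(C)CC5)cc4)nc3N)c2cc1OC`: 39 nM

In an assay on HeLa cells for inhibition of tyrosine-protein kinase receptor UFO (Homo sapiens), read by Western blot, with a stated time of 1 h (a higher number here means that more compound is needed for the effect, a lower number that less compound is needed), compound 1 gives 216 nM, the highest of the two numbers. Compound 2 gives 39 nM, a lower number beyond the scatter. Compound 3 `Cc1csc2c(-n3nc(Nc4ccc(N5CCN([C@H]6C[C@@H]7CC[C@H]6C7)CC5)c(Cl)c4)nc3N)nc(Cl)nc12` differs from compound 1 only in configuration: the two compounds have the same atoms and bonds and differ only in configuration as drawn: 3 of 3 stereo elements differ (all stereocentres are inverted: mirror images); a stereocentre at a saturated ring carbon is drawn R in compound 1 and S in compound 3; a stereocentre at a saturated ring carbon is drawn S in compound 1 and R in compound 3; a stereocentre at a saturated ring carbon is drawn R in compound 1 and S in compound 3. Going by the values given here, no measured pair differs only in configuration, so the size of such a step in this assay is unknown here. The step of a 1.2-fold higher number from compound 1 to compound 3 (0.06 log units; within the scatter) is expected to be small, probably none beyond the scatter, with a wide range in either direction. Compound 3 is estimated at 250 nM, between 60 nM and 1000 nM.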

Compound 3, half-maximal effective concentration: 136 nM
Estimate against measurement, compound 3: 1.8-fold (0.26 log units) above; low and high end bracket the measured number.
By their numbers in this assay, from the lowest: compound 2; then compounds 3 and 1 (each within the scatter of the next).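

In this assay, inverting all three stereocentres at saturated ring carbons gives a 1.6-fold lower number from compound 1 to compound 3 (0.20 log units; within the scatter), so the mirror images are not separated here. This is the first read on configuration in the series, and it is free of other structural changes: the fact that compounds 1 and 3 differ only in the configuration as drawn

As far as these compounds go, whether inverting only one stereocentre, or replacing the saturated ring group with an ethyl or a carboxylic acid, would move the number beyond the scatter stays open. Compound 2 differs from compound 1 in more than one place and cannot settle this.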